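A few compounds are considered here, and "the series" means these few. Any claim that something is new, unique, unknown or untested is made for them only; others in the source may bear on it.

For the measured compounds named here, in an assay on HEK293 cells for displacement of a labelled ligand from serine/threonine-protein kinase 17A (Homo sapiens), read by NanoBRET (on this read-out lower numbers stand for stronger inhibition and higher numbers for weaker inhibition), compound 3 `O=C(NCCCNc1ccnc(Nc2cccc(NC(=O)N3CCCC3)c2)n1)C1CCC1` gives 2310 nM, the only plain number among the three compounds measured so far. Compound 1 `NS(=O)(=O)c1ccc(CNc2nc(Nc3cccc(NC(=O)N4CCCC4)c3)ncc2Br)cc1` sits at the limit of this assay, at > 10000 nM. Compound 2 `NS(=O)(=O)c1ccc(CNc2ccnc(Nc3cccc(NC(=O)N4CCCC4)c3)n2)cc1` likewise sits at the limit, at > 10000 nM. Between them, the change of side chain brought an at least 4.3-fold lower number from compound 2 to compound 3 (0.63 log units; beyond the scatter). Compound 4 `O=C(NCCCNc1nc(Nc2cccc(NC(=O)N3CCCC3)c2)ncc1Br)C1CCC1` differs from compound 3 by bromo in place of hydrogen on an aromatic carbon. Going by the values given here, the one measured step of the same kind, a step that the two limits leave unreadable from compound 1 to compound 2, cannot be sized because of the limit of > 10000 nM in this assay, at which 2 of the 3 values shown sit. No step beyond the scatter in this assay can therefore be called for in either direction. Compound 4 is expected to give about 2000 nM, estimated between 600 nM and 7000 nM. That estimate means a 1.2-fold lower number from compound 3 to compound 4 (0.06 log units; within the scatter), expected to stay within the scatter.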

Compound 4, half-maximal inhibitory concentration: 4.47 nM
Estimate against measurement, compound 4: 450-fold (2.65 log units) above; measured number outside the range, below it.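

On the shared core, bromo in place of hydrogen on this aromatic carbon, ortho to a large group and two atoms from the ring nitrogen, gives a 520-fold lower number from compound 3 to compound 4 (2.71 log units; beyond the scatter) in this assay, the first readable size for this change. The same change from compound 1 to compound 2 cannot be read: the limit of > 10000 nM in this assay, at which 2 of the 4 values shown sit. With bromo present, the side-chain change gives an at least 2200-fold lower number from compound 1 to compound 4 (3.34 log units; beyond the scatter): the same change on two cores in this assay, an at least 4.3-fold lower number (0.63 log units; beyond the scatter) from compound 2 to compound 3 and an at least 2200-fold lower number (3.34 log units; beyond the scatter) from compound 1 to compound 4; the limit leaves it open whether they differ. The compounds shown leave open what chloro, methyl or a nitrile would give on this carbon, and how large the bromo step is with the 4-sulfamoylphenyl side chain.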